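The source may report more compounds than this note shows. Statements on the series, on what has been measured and on what is new or still open speak of the compounds shown alone.

Measured in a functional assay on K562 cells (Homo sapiens) for cytotoxicity, read by trypan blue exclusion, with a stated time of 96 h; on this read-out higher numbers stand for weaker inhibition and lower numbers for stronger inhibition:
- compound 1 `COc1ccc(CS(=O)(=O)/C=C/c2c(OC)cccc2OC)cc1[N+](=O)[O-]` gives 20000 nM
- compound 2 `COc1ccc(CS(=O)(=O)/C=C/c2c(OC)cccc2OC)cc1N` gives 50 nM

Compound 1 stands highest of the two. Among the compounds with values here, the only measured step is large and shows a 400-fold lower number from compound 1 to compound 2 (2.60 log units; beyond the scatter) on replacing the nitro group.

Compound 3 `COc1cc(OC)c(/C=C/S(=O)(=O)Cc2ccc(OC)c([N+](=O)[O-])c2)c(OC)c1` keeps that nitro group and differs from compound 1 by methoxy in place of hydrogen on an aromatic carbon on the other aromatic ring, para to a large group. The measured step concerns a different change, so it sets no size for this one. It shows only that a single substitution moved the number far in this pair. Within the data shown here, no methoxy step has been measured, so the direction is tentative and the range wide. A moderate shift to a lower number is expected, with the estimated step being a 4.0-fold lower number from compound 1 to compound 3 (0.60 log units; beyond the scatter) in this assay as a working figure. Compound 3 is expected at 5000 nM (estimated range 500 nM to 30000 nM).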

Compound 3, half-maximal inhibitory concentration: 2500 nM
Estimate against measurement, compound 3: 2.0-fold (0.30 log units) above; measured number inside the range.
By their numbers in this assay, from the lowest: compound 2; then compound 3; then compound 1.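

In this assay the ring carrying the two methoxy groups also responds to a single substitution: with the nitro group kept, methoxy in place of hydrogen at the carbon para to a large group gives an 8.0-fold lower number from compound 1 to compound 3 (0.90 log units; beyond the scatter) in this series. Within the data shown here, this is the only measured change on that ring, and it is modest beside the large 400-fold lower number from compound 1 to compound 2 (2.60 log units; beyond the scatter) on replacing nitro with amino on the other ring. Nothing available explains why the added methoxy lowers the number.

On these data alone, whether the methoxy step carries over to the amino-bearing compound 2 remains open. As far as these compounds go, it is also open whether another group at this carbon, such as ethoxy, hydroxy or a chlorine atom, would move the number in the same direction or by a similar amount.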